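The compounds below may be only part of what the source reports. "The series", "measured", "known", "first", "only" and "open" are said of these compounds alone.

Compound 1 `CC(C)(C)c1cc(NC(=O)Nc2ccc(-c3cn4ccccc4n3)cc2)no1` gives 3.09 nM in a functional assay on MV4-11 cells (Homo sapiens) for cytotoxicity, read by MTT assay, with a stated time of 72 h; a higher number here means a weaker inhibitor, a lower number a stronger inhibitor.
Compound 2 `CC(C)(C)c1cc(NC(=O)Nc2ccc(-c3cn4ccncc4n3)cc2)no1` gives 44.8 nM in this assay.
Compound 3 `CC(C)(C)c1cc(NC(=O)Nc2ccc(-c3cn4cccc(C(F)(F)F)c4n3)cc2)no1` reaches only a limit of this assay, recorded as > 900 nM.

All three share the same core and differ only in the fused two-ring group at one end. Compound 1 carries the lowest of the two plain numbers; the change to compound 2, which puts a ring nitrogen into the six-membered ring, costs a 14-fold higher number from compound 1 to compound 2 (1.16 log units; beyond the scatter). Compound 3 is known only as the limit of > 900 nM in this assay, at which 1 of the 3 values shown sits, so its step from compound 1 can be given only as a bound: an at least 290-fold higher number from compound 1 to compound 3 (2.46 log units; beyond the scatter).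

Compound 4 `Cc1ccn2cc(-c3ccc(NC(=O)Nc4cc(C(C)(C)C)on4)cc3)nc2c1` has not been measured. Its change from compound 1 is methyl in place of hydrogen on an aromatic carbon, sitting on the six-membered ring opposite the ring nitrogen and para to a fused ring. Both measured steps touch this same ring, and both made the number larger, one by a large amount and one beyond what the assay can report. A methyl is a smaller addition than a trifluoromethyl and leaves the ring nitrogen untouched, so a milder effect is expected: the estimated step for compound 4 is a 2.6-fold higher number from compound 1 to compound 4 (0.41 log units; beyond the scatter), a modest loss in this assay. Compound 4 is therefore estimated at 8 nM, within 2.5 nM to 30 nM.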

Compound 4, half-maximal inhibitory concentration in the MV4-11 assay: 0.79 nM
For compound 4 the middle estimate is 10-fold (1.01 log units) above the measured one, and the stated range ends above it.
By their numbers in the MV4-11 assay, from the lowest: compound 4; then compound 1; then compound 2. At a limit, above all of these: compound 3.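

Changes to this six-membered ring are not all harmful in the MV4-11 assay: methyl in place of hydrogen on this aromatic carbon gives a 3.9-fold lower number from compound 1 to compound 4 (0.59 log units; beyond the scatter), the only step shown that lowers the number, whereas the changes in compound 2 and compound 3 both raised it. For the compounds shown here, the ring therefore accepts a small added carbon group at this carbon without loss, so the earlier steps cannot be read as a rule against any addition to this ring. In a physicochemical assay for solubility (a higher number here means a more soluble compound, a lower number a less soluble compound), the same change gives a 1.2-fold lower number from compound 1 to compound 4 (0.09 log units; within the scatter), with compound 1 at 4070 ug/mL and compound 4 at 3340 ug/mL, so the two cannot be told apart there.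

On these data alone, it remains open whether this carbon would also take a group larger than methyl, such as ethyl, or one carrying other atoms, such as methoxy or an amine, and whether the number would keep falling. Nothing measured here gives a reason for the lower number of compound 4.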